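The compounds below may be only part of what the source reports. "The series", "measured", "known", "first", "only" and "open" are said of these compounds alone.

Measured so far in a functional assay on aorta (Rattus norvegicus, strain Wistar) for inhibition, with a stated time of 60 min; a higher number here means that more compound is needed for the effect, a lower number that less compound is needed:
Compound 1 `FC(F)(F)c1ccc2[nH]c(-c3ccccc3)nc2c1` — 468000 nM
Compound 2 `Oc1ccc(-c2nc3cc(C(F)(F)F)ccc3[nH]2)cc1` — 219000 nM

Compound 2 stands lowest of the two numbers in this assay, separated from compound 1 by the step of a 2.1-fold lower number from compound 1 to compound 2 (0.33 log units; beyond the scatter). Compound 3 `COc1cc(-c2nc3cc(C(F)(F)F)ccc3[nH]2)ccc1O` differs from compound 2 by methoxy in place of hydrogen on an aromatic carbon. No measured step introduces a methoxy group, so the only step shown, a 2.1-fold lower number from compound 1 to compound 2 (0.33 log units; beyond the scatter), bears on it only loosely, as a modest change on an aromatic carbon. Compound 3 is therefore estimated to give 160000 nM in this assay, within 60000 nM to 420000 nM. The step this implies, a 1.4-fold lower number from compound 2 to compound 3 (0.14 log units; within the scatter), is expected to stay within the scatter.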

Compound 3, half-maximal effective concentration: 140000 nM
Beside the measured number, compound 3's estimate is 1.1-fold (0.06 log units) above it, and the stated range covers the measured number.
By their numbers in this assay, from the lowest: compounds 3 and 2 (each within the scatter of the next); then compound 1.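

Methoxy in place of hydrogen on this aromatic carbon, ortho to a hydroxy group and meta to a large group, gives a 1.6-fold lower number from compound 2 to compound 3 (0.19 log units; within the scatter) in this assay and so leaves compound 3 not distinguishable from compound 2. The position therefore accepts methoxy with the hydroxy group in place, whereas the earlier hydroxy step, a 2.1-fold lower number from compound 1 to compound 2 (0.33 log units; beyond the scatter), lies beyond the scatter. Nothing measured on these compounds accounts for this result. From the compounds shown here alone, whether an amine, a carboxylic acid or a longer chain such as butoxy on this carbon would also stay within the scatter remains open.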